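The source may report more compounds than this note shows. Statements on the series, on what has been measured and on what is new or still open speak of the compounds shown alone.

Measured compounds
- compound 1 `CCC(CC)S(=O)(=O)c1ccc(S(=O)(=O)N2CCC[C@@H](C(=O)N3CCC(F)(F)CC3)C2)cc1`: 13 nM
- compound 2 `CCN(CC)S(=O)(=O)c1ccc(S(=O)(=O)N2CCC[C@@H](C(=O)N[C@H]3CC[C@@H](OC)CC3)C2)cc1`: 960 nM
- compound 3 `CCN(CC)S(=O)(=O)c1ccc(S(=O)(=O)N2CCC[C@@H](C(=O)N3CC[C@H](OC)C3)C2)cc1`: 2460 nM

In a functional assay on MIA PaCa-2 cells (Homo sapiens) for inhibition, read by MTT assay, with a stated time of 7 days (on this read-out higher numbers stand for weaker inhibition and lower numbers for stronger inhibition), compound 1 stands lowest of the three numbers, well apart from compound 2 and compound 3, both of which carry an amide on a different terminal group. Within the data shown here, the only measured step, a 2.6-fold higher number from compound 2 to compound 3 (0.41 log units; beyond the scatter), concerns that amide end and leaves the sulfonyl substituent untouched, so nothing measured speaks directly to a change at the sulfonyl sulfur.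

Compound 4 `CC(C)CS(=O)(=O)c1ccc(S(=O)(=O)N2CCC[C@@H](C(=O)N3CCC(F)(F)CC3)C2)cc1` differs from compound 1 by isobutyl in place of pentan-3-yl on a sulfonyl sulfur. Both groups are small branched alkyl chains with no ring, no donors and no acceptors, and the rest of the molecule, including the difluoropiperidine amide that marks compound 1 out from compound 2 and compound 3, is kept. Among the measured compounds shown here, with no step in the data bearing on this position, the expected step from compound 1 to compound 4 is small, a 1.5-fold higher number from compound 1 to compound 4 (0.19 log units; within the scatter), direction uncertain and likely within the scatter. The estimate for compound 4 is therefore 20 nM, with a range from 6 nM to 70 nM.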

Compound 4, half-maximal inhibitory concentration: 80 nM
Beside the measured number, compound 4's estimate is 4.0-fold (0.60 log units) below it; measured number above the stated range.
By their numbers in this assay, from the lowest: compound 1; then compound 4; then compound 2; then compound 3.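

Working from this assay, the sulfonyl position is not indifferent to the alkyl group it carries: a 6.2-fold higher number from compound 1 to compound 4 (0.79 log units; beyond the scatter) is a step beyond the scatter, with everything else in the molecule kept. The change is confined to pentan-3-yl giving way to isobutyl, so even an exchange between two unbranched-ring-free alkyl groups with no donors or acceptors, one carbon apart in count, registers in this cell read-out. No supporting measurement bears on what lies behind this step.

As far as these compounds go, whether a straight pentyl chain or a cyclopentyl ring on the sulfonyl sulfur would stay close to compound 1 remains open, and this single pair cannot separate the carbon count from the shape of the chain. Also open, from the compounds shown here alone, is whether the same exchange gives a step of similar size with a different amide end.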